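This account rests on a few compounds, and the source may have more. Where it says the series, first, only, none or still open, it means among the compounds named here.

Compound 1 `Cc1c(N(C)C)nc(CCCCCCCCCCO)c(O)c1C`: 24%
Compound 2 `CCCCCCCCCCCCCCCCCCCc1c(C)c(N(C)C)nc(C)c1O`: 23%
Compound 3 `CCCCCCCCCCc1nc(N(C)C)c(C)c(C)c1O`: 65%

All three were tested in a functional assay on cells (Lymphocyte, Homo sapiens) for inhibition, read by flow cytometry, using a membrane potential dye, with a stated time of 16 h, tested at 100 nM; a higher number here means a stronger effect of the compound at the concentration tested, a lower number a weaker effect. Compound 2 gives 23%, the lowest of the three numbers, yet compound 1 at 24% lies within the usual scatter of it, so no order between those two can be claimed. Compound 3, with 65%, stands well beyond the scatter above compound 2. The unmeasured compound 4 `CCCCCCCCCCCCCCCCc1c(C)c(N(C)C)nc(C)c1O` differs from compound 2 in one place: hydrogen in place of propyl on a saturated chain carbon, ten or more bonds along the chain from an aromatic carbon. Within the data shown here, the single measured step, a number 41 percentage points higher from compound 1 to compound 3 (beyond the scatter), concerns a different change, a hydroxy group replaced by hydrogen far out on the chain, and so bears on the present step only loosely, showing that the far end of a long chain can matter. Among the measured compounds shown here, no step shortens a chain alone. The step from compound 2 to compound 4 is therefore expected to be small, a number 5 percentage points higher from compound 2 to compound 4 (within the scatter), with no sure direction. Compound 4 is estimated at 28%, expected between 10% and 50%.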

Compound 4, a percentage reported as activity, at one concentration (the size of the read-out at that concentration, not a potency): 62%
The estimate for compound 4 lay 34 percentage points below the measured number; measured number above the stated range.
By their numbers in this assay, from the lowest: compounds 2 and 1 (each within the scatter of the next); then compounds 4 and 3 (each within the scatter of the next).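

In this assay, hydrogen in place of propyl on a saturated chain carbon, ten or more bonds along the chain from an aromatic carbon, gives a number 39 percentage points higher from compound 2 to compound 4 (beyond the scatter). The earlier step, a number 41 percentage points higher from compound 1 to compound 3 (beyond the scatter), showed a large change at such a distance only when a hydroxy group left, whereas here the group that leaves holds carbon alone, with 0 hydrogen-bond donors and 0 hydrogen-bond acceptors. No measurement shown explains why the number rises with this change.

Going by these compounds, it remains open how the number would move with a chain shorter than that of compound 4, or with one of a length between those of compound 4 and compound 2. The compounds shown also say nothing about a carboxylic acid or a phenyl group in place of the propyl.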